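Swapping Vinyl for Iodo on a Weakly Active Core

The source may report more compounds than this note shows. Statements on the series, on what has been measured and on what is new or still open speak of the compounds shown alone.

In a functional assay on HCT-116 cells (Homo sapiens) for cytotoxicity, with a stated time of 3 days (on this read-out lower numbers stand for stronger inhibition and higher numbers for weaker inhibition), compound 1 `C=Cc1nc2ccccc2[se]1` gives > 40000 nM, which is a limit of the assay and not a measured number. In this assay, compound 2 `CC#Cc1nc(C(=O)OCC)cs1` gives > 40000 nM, which is also only a limit. Among the measured compounds shown here, compound 1 therefore shares its place with the only other compound tested, as the limit of > 40000 nM in this assay, at which 2 of the 2 values shown sit, shows, and no exact potency is known for either. Compound 3 `Ic1nc2ccccc2[se]1` keeps the core of compound 1 and changes one group: iodo in place of vinyl on an aromatic carbon. For the measured compounds named here, no measured pair of compounds shows what a swap like this does. The expected size of the change, an at least 1.1-fold lower number from compound 1 to compound 3 (0.05 log units; that floor lies within the scatter), is therefore estimated to stay within the scatter, with no clear direction. Compound 3 is expected at 35000 nM, with an estimated range from 10000 nM to 60000 nM, and another limit result would be no surprise.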

Compound 3, half-maximal inhibitory concentration: > 40000 nM
Compound 3: only a limit was reported; the forecaster's own chance of this, stated with the estimate: 65%; middle value at least 1.1-fold (0.05 log units) away from the limit.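

In this assay compound 3 gives > 40000 nM, which is a limit of the assay and not a measured number. Compound 1 also has only a limit, and no step can be read between the two. The compounds shown leave open whether swapping vinyl for iodo changes potency at all, and how potent any of them is.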